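The source may report more compounds than this note shows. Statements on the series, on what has been measured and on what is new or still open speak of the compounds shown alone.

Measured so far in an assay on CHO cells for displacement of a labelled ligand from adenosine receptor A3 (Homo sapiens), read by scintillation counting, tested at 10 uM; a higher number here means more inhibition at the concentration tested (going by the name of the read-out), a lower number less inhibition:
compound 1 `CC(C)(C)Cc1csc(N)c1C(=O)c1ccc(Cl)cc1`: 5%
compound 2 `CC(C)(C)Cc1csc(N)c1C(=O)c1ccc(Cl)c(Cl)c1`: 10%

Compound 1 stands lowest of the two numbers in this assay; the step of a number 5 percentage points higher from compound 1 to compound 2 (within the scatter) is within the scatter, so the two compounds cannot be told apart. Compound 3 `Cc1ccc(C(=O)c2c(CC(C)(C)C)csc2N)cc1` differs from compound 1 by methyl in place of chloro on an aromatic carbon. Going by the values given here, no measured step covers methyl in place of chloro; the only step available, a number 5 percentage points higher from compound 1 to compound 2 (within the scatter), concerns chloro in place of hydrogen and was within the scatter. Nothing in the shown data therefore points to a change beyond the scatter. Compound 3 is expected to stay near compound 1, at 5% (-5% to 15%), a step of no change at the digits printed from compound 1 to compound 3 (within the scatter).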

Compound 3, a percentage reported as inhibition, at one concentration (the size of the read-out at that concentration, not a potency): 1%
For compound 3 the middle estimate is 4 percentage points above the measured one; measured number inside the range.
By their numbers in this assay, from the lowest: compounds 3, 1 and 2 (each within the scatter of the next).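

In this assay, methyl in place of chloro on an aromatic carbon, para to a large group, gives a number 4 percentage points lower from compound 1 to compound 3 (within the scatter) and so cannot be told apart from no change. The earlier step added a chloro to the ring, whereas this one replaces the chloro of compound 1 at this position with a group of the same heavy-atom count. No measured evidence bears on this result.

Still open, as far as these compounds go, is whether an amine or a carboxylic acid at this position would move the number in this assay beyond the scatter. The same holds for a longer chain there.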